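The compounds below may be only part of what the source reports. "The series", "measured", "known", "first", "only" and "open" are said of these compounds alone.

Of the compounds shown here, three with a shared core have been tested so far in a functional assay on HCT-116 cells (Homo sapiens) for cytotoxicity, read by MTT assay, with a stated time of 3 days (a higher number here means a weaker inhibitor, a lower number a stronger inhibitor), on the read-out of half-maximal inhibitory concentration. Compound 1 (`CC(C)(C)c1cc2c(N/N=C/c3ccc4c(c3)CNCC4)ncnc2s1`) stands at 0.107 ug/mL and compound 3 (`CC(C)(C)c1cc2c(N/N=C/c3ccc4c(c3)CNC4)ncnc2s1`) at 0.111 ug/mL with no difference beyond the scatter. Compound 2 (`CC(C)(C)c1cc2c(N/N=C/c3ccc(CN)cc3)ncnc2s1`) stands at 0.334 ug/mL as the highest of the three numbers, beyond the scatter from both others, which makes it the weakest inhibitor of the three.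

Compound 4 (`CC(C)(C)c1cc2c(N/N=C/c3ccc(O)cc3)ncnc2s1`) has not yet been measured. It differs from compound 2 by hydroxy in place of aminomethyl on an aromatic carbon, para to a large group. Among the compounds with values here, no measured pair shows this change, so the expectation is a loose one. Compound 1, compound 2 and compound 3 all keep a nitrogen in the part that changes, and compound 4 has none there. A moderate rise in the number is therefore expected in this assay from the value of compound 2 (0.334 ug/mL), and the expected change is a 3.0-fold higher number from compound 2 to compound 4 (0.48 log units; beyond the scatter) with wide uncertainty. In this assay the estimate for compound 4 is 1 ug/mL within an expected range of 0.3 ug/mL to 4 ug/mL on present evidence.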

Compound 4, half-maximal inhibitory concentration: 0.844 ug/mL
Estimate against measurement, compound 4: 1.2-fold (0.07 log units) above; measured number inside the range.
By their numbers in this assay, from the lowest: compounds 1 and 3 (each within the scatter of the next); then compound 2; then compound 4.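

In this assay, the aromatic carbon para to a large group now gives its first reading of a change of group: hydroxy in place of aminomethyl brings a 2.5-fold higher number from compound 2 to compound 4 (0.40 log units; beyond the scatter), so the number responds to the group held there, and compound 4, with no nitrogen in that part, gives the higher number of the pair. The counts do not separate the two groups, since aminomethyl and hydroxy each carry 1 hydrogen-bond donor, 1 hydrogen-bond acceptor and no net charge. Nothing measured here accounts for the step.

As far as these compounds go, with a single step at this position, it remains open whether the higher number follows from losing the nitrogen or from the shorter group, which hydroxymethyl or aminoethyl could help separate. From the compounds shown here alone, how methoxy or a carboxylic acid would read there also remains open.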